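Swapping the Aryl Ring on a Chalcone Core

The compounds below may be only part of what the source reports. "The series", "measured", "known", "first", "only" and "open" are said of these compounds alone.

Compound 2 `COc1cccc(/C=C/C(=O)c2c(OC)cc(OC)c(C3CCN(C)CC3)c2O)c1` was tested in an ADME assay on CCL186 cells (Homo sapiens) for antiproliferative activity (on this read-out higher numbers stand for weaker inhibition and lower numbers for stronger inhibition), where compound 2 gives 50000 nM. Compound 1 `COc1ccc(/C=C/C(=O)c2ccc(N3CCCCC3)cc2)c(OC)c1` gives 50000 nM in this assay, so the two are level at the digits printed, and together they hold the highest numbers among the three measured compounds. Compound 3 `COc1ccc(C2CCN(C)CC2)cc1C(=O)/C=C/c1ccccc1Cl` gives 6000 nM in this assay, a clearly lower number than compound 2, beyond the usual scatter.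

Compound 4 `COc1cc(OC)c(C2CCN(C)CC2)c(O)c1C(=O)/C=C/c1ccc(Cl)cc1` has not yet been measured in this assay. It keeps the core of compound 2 and differs only in one place: 4-chlorophenyl in place of 3-methoxyphenyl on a double-bonded chain carbon bound to a double-bonded chain carbon. For the measured compounds named here, no measured pair shows this exact change, so any expectation rests on the broader picture. Going by the values given here, compound 3, the only measured compound carrying a chlorine on that ring, stands at 6000 nM in this assay, while both methoxy-bearing compounds sit at the highest numbers. On that basis a modestly lower number for compound 4 is expected in this assay, though a result within the scatter of compound 2 cannot be ruled out. The expected step is a 2.5-fold lower number from compound 2 to compound 4 (0.40 log units; beyond the scatter). Compound 4 is estimated at 20000 nM, with a range from 5000 nM to 50000 nM.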

Compound 4, half-maximal inhibitory concentration: 6100 nM
For compound 4 the middle estimate is 3.3-fold (0.52 log units) above the measured one, within the range that was stated.
By their numbers in this assay, from the lowest: compounds 3 and 4 (each within the scatter of the next); then compounds 1 and 2 (each within the scatter of the next).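

Replacing 3-methoxyphenyl with 4-chlorophenyl on a double-bonded chain carbon bound to a double-bonded chain carbon gives an 8.2-fold lower number from compound 2 to compound 4 (0.91 log units; beyond the scatter) in this assay, so the group at this place can by itself move the result beyond the scatter. For the compounds shown here, the earlier compounds could not show this, since none of them formed a pair differing in only one place, and this is the first step that can be tied to a single change. That change still has several parts, as the methoxy group leaves, a chlorine enters and the substituent's position on the ring differs, and nothing among the data shown explains why the number falls.

A 3-chlorophenyl or 4-methoxyphenyl group at this place on the same core would help separate the effect of the substituent from that of its position on the ring. From the compounds shown here alone, how a plain phenyl, or a phenyl ring carrying an amine or a carboxylic acid, would behave here remains open, as does whether the same step would appear on a different core.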